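A few compounds are considered here, and "the series" means these few. Any claim that something is new, unique, unknown or untested is made for them only; others in the source may bear on it.

Working notes on the arylpropanamide series.

Three amides on the shared core have numbers in a functional assay on the whole organism (strain Swiss albino) for inhibition, with Mus musculus as the target, in the writhing test, with stated times of 60 min and 15 min, at a dose of 100 mg/kg by the oral route; a lower number here means less inhibition, a higher number more inhibition at the dose given (going by the name of the read-out). Compound 1 `COc1cc2c(cc1OC)C(CC(=O)N(C)C)CC2` gives 22.6%. Compound 2 `COc1cc2c(cc1OC)C(CC(=O)NC(C)C)CC2` gives 29.3%. Compound 3 `COc1cc2c(cc1OC)C(CC(=O)NCc1ccccc1)CC2` gives 48.1%, the highest of the three: the step of a number 18.8 percentage points higher from compound 2 to compound 3 (beyond the scatter) and the step of a number 25.5 percentage points higher from compound 1 to compound 3 (beyond the scatter) both lie beyond the scatter, so compound 3 has the highest inhibition in this assay of the measured set. The step of a number 6.7 percentage points higher from compound 1 to compound 2 (within the scatter) stays within the scatter, so the two non-benzylic amides are not separated.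

Compound 4 `COc1cc2c(cc1OC)C(CC(=O)N1CCCCC1)CC2` is not yet measured. It differs from compound 3 as follows: piperidin-1-yl in place of benzylamino on a carbonyl carbon. The change removes the aromatic ring that compound 3 carries; the entering group, like the dimethylamino of compound 1, has no aromatic ring. Within the data shown here, the steps that bear on this are a number 25.5 percentage points higher from compound 1 to compound 3 (beyond the scatter) and a number 18.8 percentage points higher from compound 2 to compound 3 (beyond the scatter), both modest gains tied to the arrival of the benzyl group; reversing that arrival is expected to cost a step of similar size in this assay, downward, with a number 20.1 percentage points lower from compound 3 to compound 4 (beyond the scatter) as the expected change. Compound 4 is therefore estimated at 28%, within a range from 15% to 42%, close to where compound 1 and compound 2 stand.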

Compound 4, a percentage reported as inhibition, in the whole organism at one dose (the size of the read-out at that dose, not a potency): 44.7%
Compound 4: middle estimate off by 16.7 percentage points, on the low side, outside the stated range (above it).
By their numbers in this assay, from the lowest: compounds 1 and 2 (each within the scatter of the next); then compounds 4 and 3 (each within the scatter of the next).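

In this assay, the step of a number 3.4 percentage points lower from compound 3 to compound 4 (within the scatter) shows that at this place, on a carbonyl carbon, the aromatic ring of benzylamino and the amide hydrogen can both be lost without a change that can be separated from the scatter. The earlier gains therefore do not belong to the benzyl group alone: piperidin-1-yl, with its six-membered non-aromatic ring, also stands clear of the isopropylamino and dimethylamino amides, with a number 15.4 percentage points higher from compound 2 to compound 4 (beyond the scatter) and a number 22.1 percentage points higher from compound 1 to compound 4 (beyond the scatter), so that among these four compounds the two amides carrying a six-membered ring sit apart from the two without one, and no compound goes against this. No measurement at hand gives an explanation for this result.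

Still open, from the compounds shown here alone, is whether the ring itself matters or only the number of carbons in the group on the carbonyl carbon, a question that an open-chain diethylamino or dipropylamino amide would address. Also open, going by these compounds, is how far the ring can vary, for instance with pyrrolidin-1-yl or with morpholin-4-yl, which brings a ring oxygen into the same place.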